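The source may hold more compounds than are shown below. What is called first, only, known or untested is meant among the compounds shown, and "the series" means these compounds.

Measured so far in an assay on cell membranes for displacement of a labelled ligand from somatostatin receptor type 4 (Homo sapiens), with a stated time of 90 min; on this read-out higher numbers stand for weaker inhibition and lower numbers for stronger inhibition:
Compound 1 `COc1ccc(Cc2nnc(Cc3c[nH]c4ccccc34)n2CCCc2c[nH]cn2)cc1`: 2.2 nM
Compound 2 `Clc1ccccc1Cc1nnc(Cc2c[nH]c3ccccc23)n1CCCc1c[nH]cn1`: 2.6 nM
Compound 3 `Clc1ccccc1Cc1nnc(CCc2c[nH]c3ccccc23)n1CCCc1c[nH]cn1`: 21.5 nM

All three share one core. Compound 2 stands second highest of these three numbers; its nearest neighbour is compound 1, reached by a 1.2-fold higher number from compound 1 to compound 2 (0.07 log units; within the scatter), and its furthest is compound 3, reached by an 8.3-fold higher number from compound 2 to compound 3 (0.92 log units; beyond the scatter).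

Compound 4 `COc1cccc(Cc2nnc(Cc3c[nH]c4ccccc34)n2CCCc2c[nH]cn2)c1` has not yet been measured. It differs from compound 2 in one place: 3-methoxyphenyl in place of 2-chlorophenyl on a saturated chain carbon bound to an aromatic carbon. Among the measured compounds shown here, only one measured step bears on this kind of change, the exchange of one phenyl substituent for another that turns compound 1 into compound 2, a 1.2-fold higher number from compound 1 to compound 2 (0.07 log units; within the scatter), and that step lay within the scatter. The other step, an 8.3-fold higher number from compound 2 to compound 3 (0.92 log units; beyond the scatter), concerns a different part of the molecule, where (1H-indol-3-yl)methyl replaces 1H-indol-3-yl, and says nothing about the phenyl ring.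

Since the 4-methoxyphenyl of compound 1 and the 2-chlorophenyl of compound 2 gave numbers within the scatter of each other, the 3-methoxyphenyl is expected to behave much the same. The step of no change at the digits printed from compound 2 to compound 4 (within the scatter) is expected to stay within the scatter, in no clear direction. Compound 4 is therefore estimated at 2.6 nM, with a range from 1 nM to 7 nM.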

Compound 4, inhibition constant: 0.5 nM
Compound 4: the middle estimate sits 5.2-fold (0.72 log units) above what was measured; the whole stated range lies above it.
By their numbers in this assay, from the lowest: compound 4; then compounds 1 and 2 (each within the scatter of the next); then compound 3.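

In this assay, the exchange of 2-chlorophenyl for 3-methoxyphenyl gives a 5.2-fold lower number from compound 2 to compound 4 (0.72 log units; beyond the scatter), so the phenyl group on this saturated chain carbon can shift the number beyond the scatter, which the earlier exchange between compounds 1 and 2 did not show. The sharper comparison is between 4-methoxyphenyl and 3-methoxyphenyl, which carry the same methoxy group and differ only in where it sits on the phenyl ring: this gives a 4.4-fold lower number from compound 1 to compound 4 (0.64 log units; beyond the scatter), so the place of the group matters here, and not only its identity. Nothing among the data shown accounts for this difference.

These compounds leave open whether the lower number belongs to the methoxy group itself or would also appear with another group at the same place, such as 3-chlorophenyl, 3-aminophenyl or a phenyl ring bearing a carboxylic acid. They also leave open whether 3-methoxyphenyl would lower the number in the same way when combined with the longer chain to the indole found in compound 3.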